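From Phenyl to Pyridin-3-yl in Compound 4

The source may report more compounds than this note shows. Statements on the series, on what has been measured and on what is new or still open speak of the compounds shown alone.

Three measured compounds frame this step: compound 1 (`Cn1nc(C(=O)Nc2ccc(-c3ccccc3)c(C(F)(F)F)c2)c(=O)c2ccccc21`), compound 2 (`Cn1cc(C(=O)Nc2cnc(-c3ccccc3)c(C(F)(F)F)c2)c(=O)c2ccccc21`) and compound 3 (`Cn1cc(C(=O)Nc2ccc(-c3ccccc3)c(C(F)(F)F)c2)c(=O)c2ccccc21`). In a physicochemical assay for solubility, in phosphate buffer, at pH 7.4 (a lower number here means a less soluble compound, a higher number a more soluble compound), compound 1 gives 1.6 ug/mL as a measured number. Compound 2 reads < 1 ug/mL here, which is a limit and not a number. Compound 3 reads < 1 ug/mL here, and this too is a limit and not a number. Compound 3 therefore stands at the limit of < 1 ug/mL in this assay, at which 2 of the 3 values shown sit, and has no number of its own.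

Compound 4 (`Cn1cc(C(=O)Nc2ccc(-c3cccnc3)c(C(F)(F)F)c2)c(=O)c2ccccc21`) keeps the core of compound 3 and carries pyridin-3-yl in place of phenyl on an aromatic carbon, ortho to a trifluoromethyl group and para to a large group. Among the compounds with values here, no pair of measured compounds shows this change on its own, so the data give no direct size for it. A small upward step in this assay is expected, one that may stay within the usual scatter. Within the data shown here, the expected reading remains low, in line with compound 1 at 1.6 ug/mL as the only number available. The estimated change is an at least 1.5-fold higher number from compound 3 to compound 4 (0.17 log units; that floor lies within the scatter) on this reasoning, and the assay may again report only a limit. Compound 4 is estimated at 1.5 ug/mL with an expected range from 0.5 ug/mL to 6 ug/mL on this reading.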

Compound 4, solubility: < 1 ug/mL
Compound 4: only a limit was reported; the forecaster's own chance of this, stated with the estimate: 45%; at least 1.5-fold (0.17 log units) between middle value and limit.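

In this assay, compound 3 and compound 4 each report only a limit and not a number, so no step can be read between these two compounds: the limit of < 1 ug/mL in this assay, at which 3 of the 4 values shown sit.

The compounds shown leave open how large a change, if any, pyridin-3-yl in place of phenyl brings to the reading in this assay.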